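The source may report more compounds than this note shows. Statements on the series, on what has been measured and on what is new or still open speak of the compounds shown alone.

The measured compounds in this set:

Compound 1, `COc1cccc(CNC(=O)c2c([N+](=O)[O-])noc2-c2ccc(Cl)cc2)c1`, gives 68600 nM.
Compound 2, `O=C(NCc1cccc(Cl)c1Cl)c1c([N+](=O)[O-])noc1-c1ccc(Cl)cc1`, gives 73700 nM.
Compound 3, `COc1cccc(CNC(=O)c2c([N+](=O)[O-])noc2-c2ccc(Cl)cc2Cl)c1`, gives 61200 nM.

All three values come from an ADME assay on J774.A1 cells (Mus musculus) for cytotoxicity, read by MTT assay, with a stated time of 48 h; on this read-out lower numbers stand for higher toxicity in this test and higher numbers for lower toxicity in this test. The three numbers sit close together, and the two single-point comparisons among them stay inside the usual scatter. From compound 1 to compound 2 the change is 2,3-dichlorophenyl in place of 3-methoxyphenyl on a saturated chain carbon bound to an amide-type nitrogen, and it gave a 1.1-fold higher number from compound 1 to compound 2 (0.03 log units; within the scatter). From compound 1 to compound 3 the change is chloro in place of hydrogen on an aromatic carbon, and it gave a 1.1-fold lower number from compound 1 to compound 3 (0.05 log units; within the scatter). Nothing in these three compounds, then, moves the read-out in a way that can be told apart from repeat measurement.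

Compound 4, `O=C(NCc1cccc(Cl)c1Cl)c1c([N+](=O)[O-])noc1-c1ccc(Cl)cc1Cl`, has not yet been measured in this assay. It differs from compound 3 by 2,3-dichlorophenyl in place of 3-methoxyphenyl on a saturated chain carbon bound to an amide-type nitrogen. This is the same change as the one from compound 1 to compound 2, made at the same place, and it occurs twice among the compounds shown. The cores carrying the change differ between the two pairs by chloro in place of hydrogen on an aromatic carbon, a difference that itself gave only a 1.1-fold lower number from compound 1 to compound 3 (0.05 log units; within the scatter).

Because the same change on the other core gave a 1.1-fold higher number from compound 1 to compound 2 (0.03 log units; within the scatter), compound 4 is expected to show a 1.1-fold higher number from compound 3 to compound 4 (0.03 log units; within the scatter) in this assay. The estimate for compound 4 is 66000 nM, with a likely range from 40000 nM to 110000 nM.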

Compound 4, half-maximal cytotoxic concentration: 81800 nM
For compound 4 the middle estimate is 1.2-fold (0.09 log units) below the measured one; the range from low to high includes it.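

Carried to the second core, the exchange of 3-methoxyphenyl for 2,3-dichlorophenyl gave a 1.3-fold higher number from compound 3 to compound 4 (0.13 log units; within the scatter) in this assay, and it agrees with the step seen on the first core: the same change on two cores in this assay, a 1.1-fold higher number (0.03 log units; within the scatter) from compound 1 to compound 2 and a 1.3-fold higher number (0.13 log units; within the scatter) from compound 3 to compound 4, 1.2-fold (0.09 log units) apart, within the scatter of two such steps. The other change, chloro in place of hydrogen on an aromatic carbon, gave a 1.1-fold higher number from compound 2 to compound 4 (0.05 log units; within the scatter), and it likewise agrees with its earlier counterpart: the same change on two cores in this assay, a 1.1-fold lower number (0.05 log units; within the scatter) from compound 1 to compound 3 and a 1.1-fold higher number (0.05 log units; within the scatter) from compound 2 to compound 4, 1.2-fold (0.09 log units) apart, within the scatter of two such steps. For the compounds shown here, both changes therefore carry from one core to the other here without any difference that can be told apart from repeat measurement, but every step in the set lies within the scatter, so this shows only that neither change moved the read-out on either core and not that a change with a real effect would transfer in the same way, nor that the agreement extends past these four compounds.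

The compounds shown leave open whether any change to this series moves the number beyond the scatter at all, since all four carry a benzyl group on the amide-type nitrogen and a nitro group on the shared core. A longer chain in place of the benzyl group, a carboxylic acid on the aromatic ring of that group, or an amine in place of the nitro group would test this more sharply than the exchanges seen so far.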